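The source may report more compounds than this note shows. Statements on the series, on what has been measured and on what is new or still open speak of the compounds shown alone.

Among the measured compounds shown here, in an ADME assay on microsomes from liver (Rattus norvegicus) for metabolic stability (on this read-out higher numbers stand for a longer-lived compound and lower numbers for a shorter-lived compound), compound 1 `Cc1nc(C(c2ccc(-c3ccc4cccc(F)c4c3)[nH]c2=O)C(C)C)[nH]c1C` gives 0.0733 h, while compound 2 `CC(C)C(c1nnc[nH]1)c1ccc(-c2ccc3cccc(F)c3c2)[nH]c1=O` gives 0.552 h, the higher of the two numbers measured so far. For the measured compounds named here, only one measured step bears on the next compound: a 7.5-fold higher number from compound 1 to compound 2 (0.88 log units; beyond the scatter). That step came with 4H-1,2,4-triazol-3-yl in place of 4,5-dimethyl-1H-imidazol-2-yl on a saturated chain carbon bound to an aromatic carbon and a saturated chain carbon. Compound 3 `CC(C)C(Cc1noc(=O)[nH]1)c1ccc(-c2ccc3cccc(F)c3c2)[nH]c1=O` is changed at that same place: a group of 7 heavy atoms (3 carbon, 2 nitrogen, 2 oxygen; one five-membered aromatic ring with 3 hetero atoms) in place of a group of 5 heavy atoms (2 carbon, 3 nitrogen; one five-membered aromatic ring with 3 hetero atoms), on a saturated chain carbon bound to an aromatic carbon and a saturated chain carbon. The earlier step shows that a swap here can move the number beyond the scatter, but one step involving a different pair of groups gives no direction for this new group. The expected step in this assay is therefore none beyond the scatter, estimated as a 1.1-fold higher number from compound 2 to compound 3 (0.04 log units; within the scatter). For compound 3 the estimate is 0.6 h, with an expected range from 0.2 h to 1.5 h.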

Compound 3, half-life: > 3 h
Compound 3 ended at the assay's limit (the forecaster's own chance of this, stated with the estimate: 3%); middle value at least 5.0-fold (0.69 log units) away from the limit.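

In this assay, the second swap at this saturated chain carbon again moves the number beyond the scatter and in the same direction as the first, giving an at least 5.4-fold higher number from compound 2 to compound 3 (0.73 log units; beyond the scatter) and, against the dimethyl imidazole, an at least 40-fold higher number from compound 1 to compound 3 (1.61 log units; beyond the scatter). The value of compound 3 is a limit rather than a number, so both steps are minimum sizes: the limit of > 3 h in this assay, at which 1 of the 3 values shown sits. The groups of compound 1 and compound 3 each hold 7 heavy atoms yet end far apart, so the heavy-atom count of the group does not by itself set the number at this place.

The entering group differs from the triazole in more than one feature, and these compounds cannot show which feature goes with the longer half-life. From the compounds shown here alone, whether a carboxylic acid at this place would give a similar result also stays open.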